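The source may report more compounds than this note shows. Statements on the series, on what has been measured and on what is new or still open speak of the compounds shown alone.

In a functional assay on PC-3 cells (Homo sapiens) for cytotoxicity (on this read-out higher numbers stand for weaker inhibition and lower numbers for stronger inhibition), so far:
- compound 1 `CSc1ccc(/C=N/c2nnc[nH]2)cc1` gives > 30000 nM as a limit
- compound 2 `Oc1ccccc1/C=N/n1cnnc1` gives > 30000 nM as a limit
- compound 3 `Oc1ccc(Cl)cc1/C=N/n1cnnc1` gives > 30000 nM as a limit

Compound 3 holds only the limit > 30000 nM and no number. The series as a whole shows the limit of > 30000 nM in this assay, at which 3 of the 3 values shown sit, and nothing finer. Compound 4 `Oc1ccc(Br)cc1/C=N/n1cnnc1` is reached from compound 3 through bromo in place of chloro on an aromatic carbon in a single exchange. For the measured compounds named here, the only measured step of this kind is a step that the two limits leave unreadable from compound 2 to compound 3 and offers no size to carry over, so in this assay no step beyond the scatter is expected in either direction. The expected step is a step that the limit leaves unreadable from compound 3 to compound 4 as an estimate only. The estimated value for compound 4 is 40000 nM with a range from 20000 nM to 80000 nM and a report as a limit is again likely.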

Compound 4, half-maximal inhibitory concentration: > 30000 nM
Compound 4 gave a limit, no number; the forecaster's own chance of this, stated with the estimate: 90%; the middle value does not contradict the limit.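

For the compounds shown here, compound 2, compound 3 and compound 4 all stand as limits in this assay, so no step among them can be read. The compounds shown leave open whether chloro and bromo differ at all in this read-out: the limit of > 30000 nM in this assay, at which 4 of the 4 values shown sit.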